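The compounds below may be only part of what the source reports. "The series", "measured", "known", "first", "only" and "open" are said of these compounds alone.

In a functional assay on HT-29 cells (Homo sapiens) for cytotoxicity, read by MTT assay, with a stated time of 72 h (on this read-out lower numbers stand for stronger inhibition and higher numbers for weaker inhibition), compound 1 (`Cc1ccc(NC(=O)CN2CCN(c3nnc(Cc4ccncc4)c4ccccc34)CC2)c(C)c1`) gives 1930 nM, compound 2 (`O=C(CN1CCN(c2nnc(Cc3ccncc3)c3ccccc23)CC1)Nc1ccc(F)c(C(F)(F)F)c1`) gives 1110 nM and compound 3 (`O=C(CN1CCN(c2nnc(Cc3ccncc3)c3ccccc23)CC1)Nc1cc(C(F)(F)F)ccc1Cl`) gives 4810 nM. That last number is the highest of the three, so compound 3 is the weakest inhibitor measured so far.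

Compound 4 (`Cc1ccccc1NC(=O)CN1CCN(c2nnc(Cc3ccncc3)c3ccccc23)CC1`) has not been measured yet. Its structure differs from that of compound 3 as follows: 2-methylphenyl in place of 2-chloro-5-(trifluoromethyl)phenyl on an amide-type nitrogen. In words, 2-methylphenyl stands in place of 2-chloro-5-(trifluoromethyl)phenyl on an amide-type nitrogen.

Within the data shown here, no measured step makes exactly this change, but three bear on it. The closest guide is a 2.5-fold higher number from compound 1 to compound 3 (0.40 log units; beyond the scatter), where 2,4-dimethylphenyl gives way to 2-chloro-5-(trifluoromethyl)phenyl. Run backwards, that step swaps the same group for the nearest measured relative of 2-methylphenyl. A second guide is a 4.3-fold higher number from compound 2 to compound 3 (0.64 log units; beyond the scatter), which shows that another replacement of this group also separates clearly from compound 3. The third, a 1.7-fold lower number from compound 1 to compound 2 (0.24 log units; within the scatter), shows that the two other groups tested do not separate from each other.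

Removing the 2-chloro-5-(trifluoromethyl)phenyl group is therefore expected to lower the number modestly. In this assay the expected change is a 2.2-fold lower number from compound 3 to compound 4 (0.34 log units; beyond the scatter). For compound 4 the estimated value is 2200 nM, with an expected range from 900 nM to 5000 nM.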

Compound 4, half-maximal inhibitory concentration: 15000 nM
Compound 4: middle estimate off by 6.8-fold (0.83 log units), on the low side, and the stated range ends below it.
By their numbers in this assay, from the lowest: compounds 2 and 1 (each within the scatter of the next); then compound 3; then compound 4.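

In this assay, the clearest new lesson comes from one methyl group: placing hydrogen where a methyl stood on an aromatic carbon of the 2,4-dimethylphenyl ring gives a 7.8-fold higher number from compound 1 to compound 4 (0.89 log units; beyond the scatter) and so shows that this ring on the amide-type nitrogen responds clearly to a very small edit. The earlier compounds shown here put the 2-chloro-5-(trifluoromethyl)phenyl group at the weak end, yet the 2-methylphenyl group lies further out still, with a 3.1-fold higher number from compound 3 to compound 4 (0.49 log units; beyond the scatter) and, measured against the 4-fluoro-3-(trifluoromethyl)phenyl group, a 14-fold higher number from compound 2 to compound 4 (1.13 log units; beyond the scatter) as well. Compound 4 is therefore the weakest of the four, and among these compounds the ring with a single methyl group gives a higher number than all three rings that carry two groups, whether those are methyl, halogen or trifluoromethyl.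

Among these compounds, nothing available here explains why removing one methyl group shifts the number so far. On these data alone, it also remains open whether a 4-methylphenyl group, a plain phenyl ring or a ring bearing a methoxy group would sit nearer compound 1 or compound 4, which would show whether any second group helps or only particular ones do.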